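Swapping a thiophene for a furan on an imidazoline ether

A few compounds are considered here, and "the series" means these few. Any claim that something is new, unique, unknown or untested is made for them only; others in the source may bear on it.

Measured so far:
- compound 1, `c1ccc(-c2ccncn2)c(OCC2=NCCN2)c1`, gives in a functional assay for activation of Alpha-1A adrenergic receptor (Homo sapiens), read by calcium flux (on this read-out higher numbers stand for an effect only at larger amounts of compound and lower numbers for an effect already at smaller amounts), only a limit, < 100000 nM.
- compound 2, `c1csc(-c2ccccc2OCC2=NCCN2)c1`, gives in this assay 1 nM.

Compound 2 holds the only real number shown; the other value is a limit. Among the compounds with values here, the one measured change is a step that the limit leaves unreadable from compound 1 to compound 2, and its size cannot be read since compound 1 sits at the limit of < 100000 nM in this assay, at which 1 of the 2 values shown sits.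

Compound 3, `c1ccc(-c2ccoc2)c(OCC2=NCCN2)c1`, has not been measured. It differs from compound 2 by furan-3-yl in place of thiophen-2-yl on an aromatic carbon. Within the data shown here, no measured step covers this swap of one five-membered ring for another, so the expectation rests on compound 2 alone, with wide uncertainty: a modest loss is the guess, though a change within the scatter cannot be ruled out. The expected step is a 15-fold higher number from compound 2 to compound 3 (1.18 log units; beyond the scatter). For compound 3 in this assay the estimate is 15 nM, with a range from 2 nM to 150 nM.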

Compound 3, half-maximal effective concentration: 0.501 nM
Compound 3: middle estimate off by 30-fold (1.48 log units), on the high side; the measured number lies below the stated range.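

In this assay, the swap gives a 2.0-fold lower number from compound 2 to compound 3 (0.30 log units; within the scatter), so this position accepts either of these two five-membered aromatic rings, each with 1 hetero atom. Activity of this order is therefore not tied to sulfur or to thiophen-2-yl alone, as the earlier compounds left possible. The steps from compound 1 to the other two still cannot be read, as its value is only a limit: the limit of < 100000 nM in this assay, at which 1 of the 3 values shown sits.

Going by these compounds, this swap alters the hetero atom and the ring's attachment together, so the effect of each alone remains open; a furan-2-yl or thiophen-3-yl group would separate them. On these data alone, how far the tolerance at this position extends also remains open, for example to a plain phenyl ring or to an open chain such as an amine.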